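Hydroxy Replaced by (4-Fluorobenzyl)sulfanyl on a Shared Core

The source may report more compounds than this note shows. Statements on the series, on what has been measured and on what is new or still open speak of the compounds shown alone.

For the measured compounds named here, in a functional assay on RAW264.7 cells (Mus musculus) for inhibition, with stated times of 2 h and 24 h (a higher number here means a weaker inhibitor, a lower number a stronger inhibitor), compound 1 `COc1ccc([C@@H]2c3c(OC)cc(OC)cc3C(O)[C@H]2c2cc(OC)cc(OC)c2)cc1` gives 7870 nM, the higher of the two numbers so far, while compound 2 `COc1cc(OC)cc([C@@H]2C(O)c3cc(OC)cc(OC)c3[C@H]2c2ccccc2)c1` gives 3380 nM. Compound 3 `COc1ccc([C@@H]2c3c(OC)cc(OC)cc3C(SCc3ccc(F)cc3)[C@H]2c2cc(OC)cc(OC)c2)cc1` differs from compound 1 by one change: (4-fluorobenzyl)sulfanyl in place of hydroxy on a saturated ring carbon. Going by the values given here, the only measured step, a 2.3-fold lower number from compound 1 to compound 2 (0.37 log units; beyond the scatter), comes from a different change, hydrogen in place of methoxy on an aromatic carbon, so it offers only a loose guide. Among the compounds with values here, no measured compound alters the hydroxy. A similarly modest move in this assay is therefore expected, tentatively toward a lower number: a 2.2-fold lower number from compound 1 to compound 3 (0.35 log units; beyond the scatter). For compound 3 the estimated value is 3500 nM, within an expected range of 900 nM to 14000 nM.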

Compound 3, half-maximal inhibitory concentration: > 200000 nM
Compound 3: a limit, no number (the forecaster's own chance of this, stated with the estimate: 10%); at least 57-fold (1.75 log units) between middle value and limit.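

At this saturated ring carbon, an at least 25-fold higher number from compound 1 to compound 3 (1.40 log units; beyond the scatter) follows when (4-fluorobenzyl)sulfanyl takes the place of hydroxy, so this position is far from indifferent to the change. The earlier compounds shown here showed only a modest step, at an aromatic carbon, and nothing about this carbon. In this assay, compound 3 gives a limit and not a number: the limit of > 200000 nM in this assay, at which 1 of the 3 values shown sits.

The compounds shown cannot separate the loss of the hydroxy from the arrival of the (4-fluorobenzyl)sulfanyl group. Going by these compounds, whether an amine or a methoxy at this carbon would stay close to compound 1 remains open.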